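This account rests on a few compounds, and the source may have more. Where it says the series, first, only, none or still open, it means among the compounds named here.

Measured so far in a functional assay on NCI-H1975 cells (Homo sapiens) for antiproliferative activity, with a stated time of 72 h; a higher number here means a weaker inhibitor of growth, a lower number a stronger inhibitor of growth:
- compound 1 `COc1cc(CN(C)C(=O)c2cc(Cl)c(O)cc2O)c(Cl)c(OC)c1OC`: 33800 nM
- compound 2 `COc1cc(CN(C)C(=O)c2cc(Cl)c(O)cc2O)cc(OC)c1OC`: 73100 nM

Of these two, compound 2 has the higher number, at 73100 nM, and is the weaker inhibitor of growth. Compound 1 is its nearest and only neighbour.

Next is compound 3 `COc1cc(CN(C)C(=O)c2cc(Cl)c(O)cc2O)c(Br)c(OC)c1OC`, which keeps the core of compound 2 and has bromo in place of hydrogen on an aromatic carbon.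

Within the data shown here, one measured step bears on this change: a 2.2-fold higher number from compound 1 to compound 2 (0.34 log units; beyond the scatter). It is modest and has hydrogen in place of chloro on the same aromatic carbon. Read in reverse, the halogen goes with the lower number, but this rests on a single pair, and no bromo compound has been measured yet.

A step of similar modest size towards a lower number is therefore expected in this assay, which would put compound 3 close to compound 1. The expected step is a 2.3-fold lower number from compound 2 to compound 3 (0.36 log units; beyond the scatter). In this assay the estimate for compound 3 is 32000 nM, with an expected range of 15000 nM to 65000 nM.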

Compound 3, concentration for 50% growth inhibition: 34300 nM
Compound 3: the middle estimate sits 1.1-fold (0.03 log units) below what was measured; the measured number falls inside the stated range.
By their numbers in this assay, from the lowest: compounds 1 and 3 (each within the scatter of the next); then compound 2.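

In this assay, among these compounds, the lower number seen with chloro at this aromatic carbon, ortho to a large group, is no longer a single pair: bromo in place of hydrogen gives a 2.1-fold lower number from compound 2 to compound 3 (0.33 log units; beyond the scatter). Swapping one halogen for the other at the same carbon gives a 1.0-fold higher number from compound 1 to compound 3 (0.01 log units; within the scatter), so the two halogens cannot be told apart in this read-out, and across these three compounds both go with a lower number than hydrogen, with none going against this. No measurement in hand gives a reason for this link between halogen and lower number.

Still open, going by these compounds, is whether the link is specific to halogens, since a methyl, a nitrile or a trifluoromethyl at this carbon would test whether a non-halogen group does the same, and fluoro and iodo would show whether the match between chloro and bromo extends across the halogens. Also open, on these data alone, is whether the same step appears when the rest of the molecule changes, for example with an amine added elsewhere on the shared core.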